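Chloropyridinyl amide swap on two heteroaryl cores

The source may hold more compounds than are shown below. What is called first, only, known or untested is meant among the compounds shown, and "the series" means these compounds.

Measured so far:
compound 1, `Cc1noc(C)c1-c1cnc(N)c(Oc2ccc(C(=O)Nc3ccc(Cl)cn3)cc2)n1`, 45600 nM
compound 2, `Cc1noc(C)c1-c1cnc(N)c(Oc2ccc(C(=O)Nc3cc(Cl)ccn3)cc2)n1`, 70800 nM
compound 3, `Cn1cc(-c2cnc(N)c(Oc3ccc(C(=O)Nc4ccc(Cl)cn4)cc3)n2)cn1`, 22200 nM

All three numbers come from a functional assay on U-87MG ATCC cells for inhibition, with U-87 MG (Homo sapiens) as the target, read by MTT assay, with a stated time of 72 h; a higher number here means a weaker inhibitor, a lower number a stronger inhibitor. Compound 1 and compound 2 differ only by 4-chloropyridin-2-yl in place of 5-chloropyridin-2-yl on an amide-type nitrogen, and the step is a 1.6-fold higher number from compound 1 to compound 2 (0.19 log units; within the scatter). Compound 3 carries a different group on the shared core, (1-methyl-1H-pyrazol-4-yl in place of 3,5-dimethyl-1,2-oxazol-4-yl on an aromatic carbon), and the step is a 2.1-fold lower number from compound 1 to compound 3 (0.31 log units; beyond the scatter); compound 3 gives the lowest number of the three measured.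

Compound 4, `Cn1cc(-c2cnc(N)c(Oc3ccc(C(=O)Nc4cc(Cl)ccn4)cc3)n2)cn1`, is not yet measured. It differs from compound 3 by 4-chloropyridin-2-yl in place of 5-chloropyridin-2-yl on an amide-type nitrogen, the same change that separates compound 1 from compound 2, with the same surroundings at the place of attachment. Going by the values given here, the single measured example of this change, a 1.6-fold higher number from compound 1 to compound 2 (0.19 log units; within the scatter), is within the scatter, so the expected step from compound 3 to compound 4 in this assay is estimated to be of like size, a 1.6-fold higher number from compound 3 to compound 4 (0.20 log units; within the scatter), resting only on that one pair. On that basis compound 4 is expected to give about 35000 nM, with a likely range from 17000 nM to 72000 nM.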

Compound 4, half-maximal inhibitory concentration: 47900 nM
Beside the measured number, compound 4's estimate is 1.4-fold (0.14 log units) below it, within the range that was stated.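

In this assay, 4-chloropyridin-2-yl in place of 5-chloropyridin-2-yl on the amide-type nitrogen gives a 2.2-fold higher number from compound 3 to compound 4 (0.33 log units; beyond the scatter), and this step agrees with the one on the other core: the same change on two cores in this assay, a 1.6-fold higher number (0.19 log units; within the scatter) from compound 1 to compound 2 and a 2.2-fold higher number (0.33 log units; beyond the scatter) from compound 3 to compound 4, 1.4-fold (0.14 log units) apart, within the scatter of two such steps. With 4-chloropyridin-2-yl held constant, 1-methyl-1H-pyrazol-4-yl in place of 3,5-dimethyl-1,2-oxazol-4-yl gives a 1.5-fold lower number from compound 2 to compound 4 (0.17 log units; within the scatter), and this step likewise agrees with its earlier counterpart: the same change on two cores in this assay, a 2.1-fold lower number (0.31 log units; beyond the scatter) from compound 1 to compound 3 and a 1.5-fold lower number (0.17 log units; within the scatter) from compound 2 to compound 4, 1.4-fold (0.14 log units) apart, within the scatter of two such steps. Each change therefore carries over between the two cores within these four compounds, but one matched set of four, with steps this small, does not show that either change would transfer to a further core or to other amide groups.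

The compounds shown leave open whether a larger shift in the number could come from replacing the chloropyridinyl group with an unsubstituted phenyl or a 5-methoxypyridin-2-yl group. They also leave open what a saturated amine such as morpholine or piperazine would do in place of the two five-membered heteroaryl groups.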